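Chloro on compound 1: notes on the series

The source may report more compounds than this note shows. Statements on the series, on what has been measured and on what is new or still open speak of the compounds shown alone.

Measured in a functional assay on HL60/MX2 cells (Homo sapiens) for antiproliferative activity, read by MTT assay, with a stated time of 48 h (a higher number here means a weaker inhibitor, a lower number a stronger inhibitor), so far:
- compound 1 `CN(C)CCn1c(N)c(-c2nc3ccccc3[nH]2)c2nc(C#N)c(C#N)nc21` gives 3780 nM
- compound 2 `CCCn1c(N)c(-c2nc3ccccc3[nH]2)c2nc(C#N)c(C#N)nc21` gives > 50000 nM (a limit of the assay, not a number)
- compound 3 `CN(C)CCn1c(N)c(-c2nc3ccccc3n2C)c2nc(C#N)c(C#N)nc21` gives 4680 nM

Going by the values given here, compound 1 is one of only two compounds with a numerical value, and compound 3 lies within the scatter of it. Compound 4 `CN(C)CCn1c(N)c(-c2nc3cc(Cl)ccc3[nH]2)c2nc(C#N)c(C#N)nc21` keeps the core and side chain of compound 1 and differs by chloro in place of hydrogen on an aromatic carbon only: chloro in place of hydrogen on an aromatic carbon.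

Among the compounds with values here, no measured step changes an aromatic carbon, so the evidence is indirect. Methyl in place of dimethylamino on the chain gave an at least 13-fold higher number from compound 1 to compound 2 (1.12 log units; beyond the scatter) and marks the one large step, but compound 4 keeps that chain intact. Methyl in place of hydrogen on an aromatic nitrogen gave a 1.2-fold higher number from compound 1 to compound 3 (0.09 log units; within the scatter) and is the closer guide, as the only measured change outside the chain. A modest step in this assay is therefore expected, with a slightly lower number favoured but the direction uncertain. The expected change is a 1.4-fold lower number from compound 1 to compound 4 (0.13 log units; within the scatter) and it may not clear the scatter. For compound 4 the estimated value is 2800 nM in this assay. The expected range runs from 900 nM to 9000 nM for this compound.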

Compound 4, half-maximal inhibitory concentration: > 50000 nM
Compound 4: a limit, no number (the forecaster's own chance of this, stated with the estimate: 3%); at least 17-fold (1.25 log units) between middle value and limit.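

Chloro in place of hydrogen on an aromatic carbon gives an at least 13-fold higher number from compound 1 to compound 4 (1.12 log units; beyond the scatter) in this assay, so this six-membered aromatic ring of carbon only is a place where a single heavy atom can matter as much as the side chain. Going by these compounds alone, until now the only large step lay on the chain, and the one change outside it, a 1.2-fold higher number from compound 1 to compound 3 (0.09 log units; within the scatter), stayed within the scatter; compound 4 shows that keeping the dimethylamino chain intact is not enough to retain a numerical value. Compound 4 gives > 50000 nM, which is a limit of the assay and not a number, so the step is a lower bound and its true size cannot be read, nor can it be ranked against the step to compound 2: the limit of > 50000 nM in this assay, at which 2 of the 4 values shown sit.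

Going by these compounds, it remains open whether this outcome belongs to chloro itself or to any group on this carbon, which fluoro, methyl or methoxy in the same place would help to separate. Also open, on these data alone, is whether chloro on another carbon of the same ring behaves alike, and whether a longer chain carrying the amine could restore a numerical value.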